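This account rests on a few compounds, and the source may have more. Where it says the series, first, only, none or still open, it means among the compounds named here.

Compound 2 `COc1cc(Br)cc2c1OC(N)=C(C#N)C2CC(=O)c1ccccc1` gives 45.9% in an ADME assay on MCF-10A cells (Homo sapiens) for cytotoxicity, read by sulforhodamine B assay, with a stated time of 72 h, tested at 10 uM; on this read-out higher numbers stand for a stronger effect at the one concentration tested and lower numbers for a weaker effect. Compound 1 `O=C(/C=C/c1cc(Br)ccc1O)c1ccc(Br)cc1` gives 32.8% in this assay.

Of these two numbers, compound 2 stands highest, and the gap from compound 1 lies beyond the usual scatter of this measurement. Compound 3 `COc1cccc(C(=O)CC2C(C#N)=C(N)Oc3c(OC)cc(Br)cc32)c1` has not been measured yet. It differs from compound 2 in one place: methoxy in place of hydrogen on an aromatic carbon. The new group sits meta to a large group on a six-membered aromatic ring of carbon only, so the outer part reads phenyl to 3-methoxyphenyl.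

Within the data shown here, no pair of measured compounds differs in a single place, so nothing here shows how such a change moves the read-out. The step from compound 2 is therefore expected to be small, a number 0.9 percentage points lower from compound 2 to compound 3 (within the scatter), not beyond the scatter in either direction. On that basis compound 3 is estimated at 45%, with a range from 25% to 65%.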

Compound 3, a percentage reported as activity, at one concentration (the size of the read-out at that concentration, not a potency): 32.3%
Compound 3: the middle estimate sits 12.7 percentage points above what was measured; the measured number falls inside the stated range.
By their numbers in this assay, from the lowest: compounds 3 and 1 (each within the scatter of the next); then compound 2.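

Turning phenyl into 3-methoxyphenyl is the first single change that can be read in this assay, and it gives a number 13.6 percentage points lower from compound 2 to compound 3 (beyond the scatter), a weaker effect at the one concentration tested. The outer part of compound 2 is therefore not indifferent to change at this place, meta to a large group on the six-membered aromatic ring: methoxy in place of hydrogen is enough to move the read-out beyond the usual scatter. Nothing available here explains why the number falls.

This single step cannot show whether the drop belongs to methoxy itself or would follow any group at this place, such as a hydroxyl, an amine or a longer ethoxy chain. It also leaves open what methoxy would do elsewhere on the same ring.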